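Ester in Place of Acid on a Nucleoside Amine Side Chain

This account rests on a few compounds, and the source may have more. Where it says the series, first, only, none or still open, it means among the compounds named here.

Measured compounds:
Compound 1, `Cc1cn([C@@H]2O[C@H](CO[Si](C)(C)C(C)(C)C)[C@@]3(OS(=O)(=O)C=C3NCC(=O)O)[C@H]2O[Si](C)(C)C(C)(C)C)c(=O)n(C)c1=O`: 65000 nM
Compound 2, `CCOC(=O)NC(=O)NC1=CS(=O)(=O)O[C@@]12[C@@H](CO[Si](C)(C)C(C)(C)C)O[C@@H](n1cc(C)c(=O)n(C)c1=O)[C@@H]2O[Si](C)(C)C(C)(C)C`: 3000 nM
Compound 3, `CCOC(=O)CNC(=O)NC1=CS(=O)(=O)O[C@@]12[C@@H](CO[Si](C)(C)C(C)(C)C)O[C@@H](n1cc(C)c(=O)n(C)c1=O)[C@@H]2O[Si](C)(C)C(C)(C)C`: 5020 nM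

In a functional assay on CCRF-CEM cells (Homo sapiens) (on this read-out higher numbers stand for lower toxicity in this test and lower numbers for higher toxicity in this test), compound 1 stands highest of the three numbers; the nearest is compound 3, the furthest compound 2. The two steps away from compound 1 both go the same way: a 22-fold lower number from compound 1 to compound 2 (1.34 log units; beyond the scatter) and a 13-fold lower number from compound 1 to compound 3 (1.11 log units; beyond the scatter). Compound 2 and compound 3 differ little from each other, a 1.7-fold higher number from compound 2 to compound 3 (0.22 log units; within the scatter).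

Compound 4, `COC(=O)C(=O)CNC1=CS(=O)(=O)O[C@@]12[C@@H](CO[Si](C)(C)C(C)(C)C)O[C@@H](n1cc(C)c(=O)n(C)c1=O)[C@@H]2O[Si](C)(C)C(C)(C)C`, has not been measured. It differs from compound 1 in one place: methoxycarbonyl in place of hydroxy on a carbonyl carbon. As in the two measured steps, the carboxy group of compound 1 is lost; unlike them, the amine nitrogen keeps its chain. On that basis a lower number is expected in this assay, of moderate size, an 8.1-fold lower number from compound 1 to compound 4 (0.91 log units; beyond the scatter). Compound 4 is estimated at 8000 nM, within 2500 nM to 25000 nM.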

Compound 4, half-maximal cytotoxic concentration: 5570 nM
Compound 4: middle estimate off by 1.4-fold (0.16 log units), on the high side; low and high end bracket the measured number.
By their numbers in this assay, from the lowest: compounds 2, 3 and 4 (each within the scatter of the next); then compound 1.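

In this assay, methoxycarbonyl in place of hydroxy on the carbonyl carbon gives a large step (a 12-fold lower number from compound 1 to compound 4 (1.07 log units; beyond the scatter)), so a large step away from compound 1 does not require the carbamoyl link of compound 2 and compound 3. Compound 4 stays within the scatter of both (a 1.1-fold higher number from compound 3 to compound 4 (0.05 log units; within the scatter); a 1.9-fold higher number from compound 2 to compound 4 (0.27 log units; within the scatter)). No evidence is available on what lies behind these numbers. Still open, on these data alone, is whether a primary amide or a simple ethyl ester on the carboxymethyl chain, or a longer chain carrying the carboxylic acid, would behave like compound 1 or compound 4.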